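Substituent swap on the aromatic ring: compound 2 to compound 3

A few compounds are considered here, and "the series" means these few. Any claim that something is new, unique, unknown or untested is made for them only; others in the source may bear on it.

Measured so far:
- compound 1 `O=C(CCCc1ccc([N+](=O)[O-])cn1)N1CCc2c(Cl)c(O)c(O)c(Cl)c2C1`: 33%
- compound 2 `O=C(CCCc1ncc(C(F)(F)F)cc1Cl)N1CCc2c(Cl)c(O)c(O)c(Cl)c2C1`: 5%

In a functional assay (Homo sapiens), tested at 10 uM (a lower number here means a stronger effect, a higher number a weaker effect of the compound at the concentration tested), compound 1 gives 33%. In the same conditions compound 2 gives 5%, the lowest of the two numbers; compound 1 stands higher by a margin beyond the scatter. Within the data shown here, no step between measured compounds that differ in one place is available, so the pair is read only on what its two values show.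

Compound 3 `O=C(CCCc1ncc(C(F)(F)F)cc1C1CCCCC1)N1CCc2c(Cl)c(O)c(O)c(Cl)c2C1` differs from compound 2 in one place, (cyclohexyl in place of chloro on an aromatic carbon). Nothing measured in the set shows this kind of change, so the expectation leans on the position of compound 2 alone. Since compound 2 already sits near the bottom of the scale, the expected step of a number 10 percentage points higher from compound 2 to compound 3 (within the scatter) is a small rise, possibly within the scatter. For compound 3 the estimate is 15%, with a range from 3% to 45%.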

Compound 3, a percentage reported as activity, at one concentration (the size of the read-out at that concentration, not a potency): 77%
Beside the measured number, compound 3's estimate is 62 percentage points below it; measured number above the stated range.
By their numbers in this assay, from the lowest: compound 2; then compound 1; then compound 3.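

Cyclohexyl in place of chloro on this aromatic carbon, two atoms from the ring nitrogen and meta to a trifluoromethyl group, gives in this assay a number 72 percentage points higher from compound 2 to compound 3 (beyond the scatter) and is the first one-place step in the series. The earlier pair differed in more than one place, whereas this step ties a large change in the read-out to this single position, where six carbon atoms and a non-aromatic ring replace one chlorine. Nothing available explains the size of the step.

The compounds shown leave open how the read-out changes with groups of intermediate size on this carbon, such as methyl, methoxy or cyclopropyl. They also leave open whether a phenyl ring or an amine here would give a similar step.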